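Replacing a Secondary Amide with a Tertiary One

The source may report more compounds than this note shows. Statements on the series, on what has been measured and on what is new or still open speak of the compounds shown alone.

Compound 1 `CCC(C)NC(=O)/C=C/c1c(/C=C/c2ccc(OC)cc2)cc(OC)cc1OC` is one of three stilbene-bearing amides tested in a functional assay on A549 cells (Homo sapiens) for inhibition, read by MTT assay, with a stated time of 48 h (on this read-out lower numbers stand for stronger inhibition and higher numbers for weaker inhibition), where compound 1 gives 3950 nM. Compound 2 `COc1ccc(/C=C/c2cc(OC)cc(OC)c2/C=C/C(=O)NC(C)C)cc1` gives 2360 nM and compound 3 `COc1ccc(/C=C/c2cc(OC)cc(OC)c2/C=C/C(=O)N2CCC(c3ccccc3)CC2)cc1` gives 6690 nM, so compound 1 sits second highest of the three. The unmeasured compound 4 `COc1ccc(/C=C/c2cc(OC)cc(OC)c2/C=C/C(=O)N(CC(C)C)CC(C)C)cc1` differs from compound 1 by diisobutylamino in place of (sec-butyl)amino on a carbonyl carbon. The closest precedents swap an amine bearing a hydrogen for one without: a 1.7-fold higher number from compound 1 to compound 3 (0.23 log units; within the scatter) and a 2.8-fold higher number from compound 2 to compound 3 (0.45 log units; beyond the scatter). Both point toward a somewhat higher number when that hydrogen is lost. For compound 4, a modestly higher number than compound 1 is therefore expected, a 1.6-fold higher number from compound 1 to compound 4 (0.22 log units; within the scatter). Compound 4 is estimated at 6500 nM, with a range from 3000 nM to 14000 nM.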

Compound 4, half-maximal inhibitory concentration: 3350 nM
Beside the measured number, compound 4's estimate is 1.9-fold (0.29 log units) above it, and the stated range covers the measured number.
By their numbers in this assay, from the lowest: compounds 2, 4, 1 and 3 (each within the scatter of the next, the first and the last beyond it).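

In this assay the loss of the amide hydrogen does not by itself move the number: diisobutylamino on the carbonyl carbon gives a 1.2-fold lower number from compound 1 to compound 4 (0.07 log units; within the scatter) and a 1.4-fold higher number from compound 2 to compound 4 (0.15 log units; within the scatter) with both steps within the scatter. The step from the tertiary amide of compound 3 is also within the scatter at a 2.0-fold lower number from compound 3 to compound 4 (0.30 log units; within the scatter) so a tertiary amide as such does not separate these compounds. No measurement here explains these numbers. Still open, on these data alone, is whether dimethylamino or morpholin-4-yl on the carbonyl carbon would stay within the same scatter.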